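This account rests on a few compounds, and the source may have more. Where it says the series, first, only, none or still open, it means among the compounds named here.

The compounds measured in an in vitro assay on CHO cells for displacement of a labelled ligand from Bombesin receptor subtype-3 (Homo sapiens), read by scintillation counting, with a stated time of 2 h (a higher number here means a weaker inhibitor, a lower number a stronger inhibitor), are these:

compound 1, `CCC(C)(C)Cc1c[nH]c(CCc2ccc(-c3cnccn3)cc2)n1`, 51 nM
compound 2, `CCC(C)(C)Cc1c[nH]c(CCc2ccc(-n3ccnn3)cc2)n1`, 390 nM
compound 3, `O=C(O)c1cc(F)c(F)cc1-c1ccc(CCc2nc(CC3CCCCC3)c[nH]2)cc1`, 36 nM

Compound 2 stands highest of the three numbers. Its nearest neighbour is compound 1, whose number is lower by a margin beyond the scatter, and compound 3 lies furthest from it, lower still. Among the compounds with values here, the one step between compounds that differ in a single place is a 7.6-fold higher number from compound 1 to compound 2 (0.88 log units; beyond the scatter), a modest rise in this assay on exchanging pyrazin-2-yl for 1H-1,2,3-triazol-1-yl.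

Compound 4, `CCC(C)(C)Cc1c[nH]c(CCc2ccc(-n3cncn3)cc2)n1`, has not yet been measured. It differs from compound 2 as follows: 1H-1,2,4-triazol-1-yl in place of 1H-1,2,3-triazol-1-yl on an aromatic carbon. Within the data shown here, no measured step bears directly on this exchange: the step from compound 1 to compound 2 sets pyrazin-2-yl against 1H-1,2,3-triazol-1-yl and says nothing about 1H-1,2,4-triazol-1-yl, and compound 3 carries a different group at that place altogether. The two triazoles share the same atoms and the same ring size, so the expected step in this assay is small, within or close to the scatter, with no firm direction. The step from compound 2 to compound 4 is therefore expected to be a 1.3-fold lower number from compound 2 to compound 4 (0.11 log units; within the scatter). For compound 4 the estimate in this assay is 300 nM, with a range from 100 nM to 1000 nM.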

Compound 4, half-maximal inhibitory concentration: 340 nM
Compound 4: the middle estimate sits 1.1-fold (0.05 log units) below what was measured; measured number inside the range.
By their numbers in this assay, from the lowest: compounds 3 and 1 (each within the scatter of the next); then compounds 4 and 2 (each within the scatter of the next).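

In this assay, rearranging the ring atoms from 1H-1,2,3-triazol-1-yl to 1H-1,2,4-triazol-1-yl, on an aromatic carbon para to a large group, gives a 1.1-fold lower number from compound 2 to compound 4 (0.06 log units; within the scatter), so the two triazoles cannot be told apart at this position. The comparison with pyrazin-2-yl now rests on a second triazole, with a 6.7-fold higher number from compound 1 to compound 4 (0.82 log units; beyond the scatter) beyond the scatter, so the higher number seen with 1H-1,2,3-triazol-1-yl is not confined to that one arrangement of ring atoms. Nothing measured here accounts for either result.

The compounds shown leave open whether a five-membered ring with fewer nitrogens, such as pyrazol-1-yl or imidazol-1-yl, would stand with the two triazoles or with pyrazin-2-yl, and whether a six-membered ring such as pyridin-2-yl or pyrimidin-2-yl would keep the number of compound 1. It also remains open how an amine or a carboxylic acid would fare at this same place on the core of compound 1, where only these three rings are shown.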